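The compounds below may be only part of what the source reports. "The series", "measured", "known", "first", "only" and "open" are said of these compounds alone.

Measured in an ADME assay on HEp-2 cells (Homo sapiens) for cytotoxicity, read by MTT assay, with a stated time of 72 h; on this read-out lower numbers stand for stronger inhibition and higher numbers for weaker inhibition:

- Compound 1 `C=CCOc1cc(C2=C(c3cc(OC)c(OC)c(OC)c3)C(=O)C(O)C2)ccc1OC`: > 100 ug/mL (a limit of the assay, not a number)
- Compound 2 `COc1ccc(C2=C(c3cc(OC)c(OC)c(OC)c3)C(=O)C(O)C2)cc1`: < 1 ug/mL (a limit of the assay, not a number)
- Compound 3 `COc1ccc(C2=C(c3cc(OC)c(OC)c(OC)c3)C(=O)C(O[SiH2]C(C)(C)C)C2)cc1OC(C)C`: 7.1 ug/mL

Of these three results, only compound 3 has an actual number, 7.1 ug/mL. The other two results are limits, so they fix no exact position for it.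

Compound 4 `COc1ccc(C2=C(c3cc(OC)c(OC)c(OC)c3)C(=O)C(O)C2)cc1OC(C)C` has not yet been measured. It differs from compound 3 in one place: a hydrogen atom in place of a group of 5 heavy atoms (4 carbon, 1 silicon; no ring), on an oxygen on a saturated carbon. Within the data shown here, no measured pair shows this same change, so any forecast rests on indirect evidence.

Among the measured compounds shown here, the one measured step lies elsewhere in the structure, with hydrogen in place of allyloxy on an aromatic carbon. It is an at least 100-fold lower number from compound 1 to compound 2 (2.00 log units; beyond the scatter), which is large and beyond the scatter. Compound 4 has hydrogen on the oxygen, as do compound 1 and compound 2, but it carries isopropoxy where compound 1 has allyloxy and compound 2 has hydrogen. That makes compound 1 its closer match, so the evidence leans towards weak inhibition, though with much uncertainty.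

In this assay, the expected change is a 5.6-fold higher number from compound 3 to compound 4 (0.75 log units; beyond the scatter), a rise towards weaker inhibition. The estimate for compound 4 is 40 ug/mL, with an expected range of 5 ug/mL to 150 ug/mL.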

Compound 4, half-maximal inhibitory concentration: > 100 ug/mL
Compound 4: a limit, no number (the forecaster's own chance of this, stated with the estimate: 40%); middle value at least 2.5-fold (0.39 log units) from the limit.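

In this assay, among these compounds, replacing the group of 5 heavy atoms (4 carbon, 1 silicon) on the oxygen with a hydrogen atom gives an at least 14-fold higher number from compound 3 to compound 4 (1.14 log units; beyond the scatter), the first direct reading of a change at this oxygen on a saturated carbon, and it runs towards weaker inhibition. On the aromatic carbon, isopropoxy in place of hydrogen gives an at least 100-fold higher number from compound 2 to compound 4 (2.00 log units; beyond the scatter), so a second group there, alongside allyloxy in an at least 100-fold lower number from compound 1 to compound 2 (2.00 log units; beyond the scatter), goes with a large loss of inhibition while the hydrogen on the oxygen stays the same. The step between allyl and isopropyl cannot be read, and the two steps above are minimum sizes, because compound 1 and compound 4 both sit at a limit rather than at a number: the limit of > 100 ug/mL in this assay, at which 2 of the 4 values shown sit.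

Among the compounds shown here, the true size of these steps stays open, as does whether a group other than the one in compound 3, such as an acetyl ester on the same oxygen, would also give stronger inhibition than the free hydroxyl of compound 4. It is also unknown whether an amine or a fluorine on the aromatic carbon would keep the strong inhibition of compound 2 or lose it as isopropoxy does.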